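Replacing chloro with amino in a strong inhibitor

The source may report more compounds than this note shows. Statements on the series, on what has been measured and on what is new or still open speak of the compounds shown alone.

Two related compounds have been measured so far in a functional assay (aorta) for inhibition, with Rattus norvegicus as the target (a higher number here means a weaker inhibitor, a lower number a stronger inhibitor), and they set the scene. Compound 1 (`Cc1nsc(-c2ccc(N3CCN(c4cccc(Cl)c4)CC3)nn2)n1`) gives 0.6 nM as the lower of the two numbers, which makes it the stronger inhibitor of the pair. Compound 2 (`CNc1nsc(-c2ccc(N3CCN(c4cccc(C(F)(F)F)c4)CC3)nn2)n1`) gives 3 nM and the gap between the two lies beyond the usual scatter. These two compounds differ in more than one place, so their gap cannot be pinned on any single group.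

Compound 3 (`Cc1nsc(-c2ccc(N3CCN(c4cccc(N)c4)CC3)nn2)n1`) keeps the core of compound 1 and changes just one group, on an aromatic carbon meta to a large group: amino in place of chloro on an aromatic carbon (3-chlorophenyl to 3-aminophenyl). Within the data shown here, no measured pair tests amino in place of chloro, so any forecast here is a cautious judgement. A moderate loss of strength seems more likely than a gain, and the expected step is a 6.7-fold higher number from compound 1 to compound 3 (0.82 log units; beyond the scatter) toward a weaker inhibitor. The estimate for compound 3 is 4 nM with an expected range from 0.8 nM to 25 nM in this measurement.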

Compound 3, half-maximal inhibitory concentration: > 100 nM
Compound 3 gave a limit, no number; the forecaster's own chance of this, stated with the estimate: 2%; middle value at least 25-fold (1.39 log units) from the limit.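

The 3-chlorophenyl group of compound 1 cannot be swapped freely for 3-aminophenyl: in this assay, this single change gives an at least 160-fold higher number from compound 1 to compound 3 (2.22 log units; beyond the scatter), a large loss of strength. Compound 1 and compound 2 differ in more than one place and could not tie a gap to any one group, whereas here only the group on an aromatic carbon, meta to a large group, changes, so the loss belongs to amino in place of chloro. Compound 3 gives a limit of the assay, not a number: the limit of > 100 nM in this assay, at which 1 of the 3 values shown sits.

Still open, as far as these compounds go, is how weak compound 3 really is, and whether the loss goes with the hydrogen-bond donor and acceptor that amino brings in, which chloro does not have. A methyl, a methoxy or a hydroxyl group on the same aromatic carbon, or a fluoro or bromo group in place of chloro, would help to show which groups this position accepts and which it does not.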